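A few compounds are considered here, and "the series" means these few. Any claim that something is new, unique, unknown or untested is made for them only; others in the source may bear on it.

Measured so far:
compound 1 `O=C(NCc1ccc(CNS(=O)(=O)c2cccc(Cl)c2)cc1)c1ccc(F)cc1`, 1 nM
compound 2 `O=C(NCc1ccc(CNS(=O)(=O)c2ccccc2Cl)cc1)c1ccc(F)cc1`, 1000 nM

In an assay on MDA-MB-231 cells for binding affinity to C-X-C chemokine receptor type 4 (Homo sapiens), read by fluorescence and microscopy, with stated times of 10 min and 30 min (on this read-out lower numbers stand for an effect already at smaller amounts and higher numbers for an effect only at larger amounts of compound), compound 1 gives the lowest of the two numbers, and compound 2 sits a 1000-fold higher number from compound 1 to compound 2 (3.00 log units; beyond the scatter) away, a change of only the chlorine's place on the ring at the sulfonyl sulfur. Compound 3 `O=C(NCc1ccc(CNS(=O)(=O)c2cccc3ccccc23)cc1)c1ccc(F)cc1` differs from compound 1 by naphthalen-1-yl in place of 3-chlorophenyl on a sulfonyl sulfur. Going by the values given here, the one measured step, a 1000-fold higher number from compound 1 to compound 2 (3.00 log units; beyond the scatter), bears on this only loosely, as it concerns a chlorine rather than a second ring; it shows that changes at this ring can matter greatly. A moderate weakening is expected, a 30-fold higher number from compound 1 to compound 3 (1.48 log units; beyond the scatter), so compound 3 is estimated at 30 nM, within 3 nM to 300 nM.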

Compound 3, effective concentration (reported as EC, without a stated level of effect): 1000 nM
Estimate against measurement, compound 3: 33-fold (1.52 log units) below, and the stated range ends below it.
By their numbers in this assay, from the lowest: compound 1; then compounds 2 and 3 (each within the scatter of the next).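

Placing a second ring on the sulfonyl sulfur proves as costly in this assay as moving the chlorine (a 1000-fold higher number from compound 1 to compound 3 (3.00 log units; beyond the scatter)). Compounds 2 and 3 cannot be told apart (no change at the digits printed from compound 2 to compound 3 (within the scatter)), so two different groups end up at the same number, and among these three compounds only 3-chlorophenyl gives the low number. No available evidence explains either loss. From the compounds shown here alone, it remains open whether the chlorine itself matters, or whether a bromine, a methoxy group or an amine in its place would keep the low number.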